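The source may report more compounds than this note shows. Statements on the series, on what has been measured and on what is new or still open speak of the compounds shown alone.

Compound 1 `CCCCc1ccc(CN)c(=O)n1Cc1ccc(-c2ccccc2-c2nn[nH]n2)cc1` gives 2.8% in a functional assay on the whole organism (artery) for inhibition, with Rattus norvegicus as the target, at a dose of 3 mg/kg by the intraduodenal route (on this read-out lower numbers stand for less inhibition and higher numbers for more inhibition at the one dose given (going by the name of the read-out)), and stands lowest of the three measured numbers. Compound 2 `CCCCc1ccc(CN(C)S(=O)(=O)c2ccccc2)c(=O)n1Cc1ccc(-c2ccccc2-c2nn[nH]n2)cc1` gives 68.7% and compound 3 `CCCCc1ccc(CN(Cc2ccccc2)S(=O)(=O)c2ccc(C)cc2)c(=O)n1Cc1ccc(-c2ccccc2-c2nn[nH]n2)cc1` gives 36.6%, both beyond the scatter above compound 1. Compound 4 `CCCCc1ccc(CN(C)S(C)(=O)=O)c(=O)n1Cc1ccc(-c2ccccc2-c2nn[nH]n2)cc1` is not yet measured; it differs from compound 1 by methyl(methylsulfonyl)amino in place of amino on a saturated chain carbon bound to an aromatic carbon. For the measured compounds named here, the one measured step that bears on it is a number 65.9 percentage points higher from compound 1 to compound 2 (beyond the scatter), a change at the same place in which the entering group is larger than in compound 4. Compound 3 is not a single-place step from compound 1, so only its value is noted. For compound 4 a rise beyond the scatter is expected, estimated as a number 42.2 percentage points higher from compound 1 to compound 4 (beyond the scatter). Compound 4 is estimated at 45%, with a range from 15% to 75%.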

Compound 4, a percentage reported as inhibition, in the whole organism at one dose (the size of the read-out at that dose, not a potency): 83.4%
The estimate for compound 4 lay 38.4 percentage points below the measured number, and the stated range ends below it.
By their numbers in this assay, from the lowest: compound 1; then compound 3; then compound 2; then compound 4.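

At the saturated chain carbon bound to an aromatic carbon, the large rise over amino is not confined to the phenylsulfonyl group, with methyl(methylsulfonyl)amino giving a number 80.6 percentage points higher from compound 1 to compound 4 (beyond the scatter) in this assay. The group on the sulfonyl sulfur also counts, since methyl in place of phenyl gives a number 14.7 percentage points higher from compound 2 to compound 4 (beyond the scatter) beyond the scatter. No evidence here accounts for either step.

Still open, from the compounds shown here alone, is how an ethyl or longer chain on the sulfonyl sulfur would read. Also open, going by these compounds, is whether an acetyl group could replace the methylsulfonyl at this place.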